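Arylsulfonate anilides on HT-29: a chain chloro step

The source may hold more compounds than are shown below. What is called first, only, known or untested is meant among the compounds shown, and "the series" means these compounds.

Measured compounds:
Compound 1 `CCCC(=O)Nc1cccc(S(=O)(=O)Oc2ccccc2C(C)C)c1`: 13000 nM
Compound 2 `CCC(=O)Nc1ccc(S(=O)(=O)Oc2ccccc2C(C)C)cc1`: 7400 nM
Compound 3 `CCC(=O)Nc1ccc(S(=O)(=O)Oc2ccccc2I)cc1`: 11000 nM

All three numbers come from a functional assay on HT-29 cells (Homo sapiens) for antiproliferative activity, read by sulforhodamine B assay, with a stated time of 48 h; a higher number here means a weaker inhibitor, a lower number a stronger inhibitor. Compound 2 gives 7400 nM, the lowest of the three, though its distance to compound 3 at 11000 nM and to compound 1 at 13000 nM is within the scatter, so no order among them can be read. Within the data shown here, the one single-point step in the set, a 1.5-fold higher number from compound 2 to compound 3 (0.17 log units; within the scatter), is within the scatter: iodo in place of isopropyl on an aromatic carbon leaves this assay unmoved.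

Compound 4 `CC(C)c1ccccc1OS(=O)(=O)c1ccc(NC(=O)CCCl)cc1` is still to be measured. It differs from compound 2 by chloro in place of hydrogen on a saturated chain carbon, two bonds along the chain from a carbonyl carbon, a change on the amide chain rather than on either aromatic ring. Among the measured compounds shown here, none of the measured steps touches that chain, so no step bears on it directly; the only guidance is that the set so far has stayed within the scatter throughout. A step no larger than the scatter is therefore expected, a 1.5-fold lower number from compound 2 to compound 4 (0.17 log units; within the scatter), leaning if at all toward a lower number. Compound 4 is estimated at 5000 nM, with a range of 2000 nM to 15000 nM.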

Compound 4, half-maximal inhibitory concentration: 16000 nM
The estimate for compound 4 lay 3.2-fold (0.51 log units) below the measured number; measured number above the stated range.
By their numbers in this assay, from the lowest: compounds 2, 3, 1 and 4 (each within the scatter of the next, the first and the last beyond it).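

In this assay, among these compounds, the amide chain is the first place where a single change moves the number beyond the scatter: the step of a 2.2-fold higher number from compound 2 to compound 4 (0.33 log units; beyond the scatter) comes with chloro in place of hydrogen on a saturated chain carbon, two bonds along the chain from a carbonyl carbon. Among the compounds shown here, the step is modest, but it shows that this chain position responds to substitution, whereas the one earlier step of a 1.5-fold higher number from compound 2 to compound 3 (0.17 log units; within the scatter) on an aromatic carbon stayed within the scatter. Nothing in the available data accounts for this step.

Going by these compounds, it remains open whether the higher number is specific to chloro or would also follow a fluoro, a hydroxyl or an amine on the same carbon. On these data alone, the same change on the chain of compound 3 also remains open.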